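Moving a methyl group around the benzyl ring

The source may report more compounds than this note shows. Statements on the series, on what has been measured and on what is new or still open speak of the compounds shown alone.

Measured so far in a functional assay on Vas deferens for antagonist activity at Alpha-1A adrenergic receptor (Rattus norvegicus); on this read-out higher numbers stand for higher potency (the scale is a negative logarithm) and lower numbers for lower potency:
Compound 1 `COc1cccc(OC)c1OCCNCCOc1ccccc1OCc1ccccc1Cl` gives 8.56.
Compound 2 `COc1cccc(OC)c1OCCNCCOc1ccccc1OCc1cccc(C)c1` gives 8.3.

Compound 2 has the lower of the two numbers, but its nearest neighbour, compound 1, sits within the usual scatter, so the two cannot be ordered. Going by the values given here, the one measured step, a number 0.26 log units lower from compound 1 to compound 2 (within the scatter), swapped a whole ring for another and still stayed within the scatter. Compound 3 `COc1cccc(OC)c1OCCNCCOc1ccccc1OCc1ccc(C)cc1` is built from compound 2 by 4-methylphenyl in place of 3-methylphenyl on a saturated chain carbon bound to an oxygen on an aromatic ring. Among the compounds with values here, no measured step shifts a methyl group on this ring, so nothing in the data points to a change in either direction. The expectation is therefore a flat step, no change at the digits printed from compound 2 to compound 3 (within the scatter), with nothing beyond the scatter, and compound 3 is estimated at 8.3 in this assay, in a range from 7.7 to 8.8.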

Compound 3, negative logarithm of the antagonist equilibrium constant: 8.23
Compound 3: the middle estimate sits 0.07 log units above what was measured; the range from low to high includes it.
By their numbers in this assay, from the lowest: compounds 3, 2 and 1 (each within the scatter of the next, the first and the last beyond it).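

In this assay, moving the methyl group from 3-methylphenyl to 4-methylphenyl gives a number 0.07 log units lower from compound 2 to compound 3 (within the scatter), so this first shift of a group around the ring cannot be told apart from no change. Replacing 2-chlorophenyl with 4-methylphenyl gives a number 0.33 log units lower from compound 1 to compound 3 (beyond the scatter), a modest step that passes the scatter, although the replacement by 3-methylphenyl did not; since compounds 2 and 3 cannot be ordered, this does not separate the two methyl placements. No measurement at hand offers an explanation for these numbers.

Still open, going by these compounds, is how 2-methylphenyl would compare, which would help show whether the chlorine or its place on the ring matters for compound 1. Also open, on these data alone, is how a very different group on this ring, such as a carboxylic acid or an amine, would fare.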